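Carbamoyl Replacement on a Core Without Measured Potency

The source may report more compounds than this note shows. Statements on the series, on what has been measured and on what is new or still open speak of the compounds shown alone.

Compound 2 `NC(=O)c1c(NC(=O)c2ccc(C(F)(F)F)cc2)sc2c1CCN(Cc1ccc(Cl)cc1)C2` is one of three close relatives tested in a functional assay on HeLa cells (Homo sapiens) for antiproliferative activity, with a stated time of 24 h; a higher number here means a weaker inhibitor, a lower number a stronger inhibitor. In this assay compound 2 gives > 50000 nM, which is a limit of the assay rather than a number. Compound 1 `NC(=O)c1c(NC(=O)c2ccccc2Cl)sc2c1CCN(Cc1ccc(Cl)cc1)C2` gives > 50000 nM in this assay, also a limit. Compound 3 `COc1ccccc1NC(=S)N1CCc2c(sc(NC(=O)c3ccccc3Cl)c2C(N)=O)C1` gives > 50000 nM in this assay, again a limit. All three values thus sit at the limit of > 50000 nM in this assay, at which 3 of the 3 values shown sit.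

Compound 4 `NC(=O)c1c(NC(=O)c2ccc(C(F)(F)F)cc2)sc2c1CCN(C(=O)Nc1ccccc1Cl)C2` has not yet been measured. It differs from compound 2 by (2-chlorophenyl)carbamoyl in place of 4-chlorobenzyl on an amine nitrogen in a ring. For the measured compounds named here, two measured steps bear on this. The change on the carbonyl carbon, a step that the two limits leave unreadable from compound 1 to compound 2, and the change on the ring amine nitrogen, a step that the two limits leave unreadable from compound 1 to compound 3, both run between limits, so neither gives a readable size or direction. No measured step therefore points the way for the change to compound 4, and the shared core has shown no measurable potency in any tested form. The expected step in this assay is a number no higher from compound 2 to compound 4 (the limit leaves the size open). Compound 4 is estimated to give 50000 nM, within 15000 nM to 200000 nM, most probably reported once more only as a limit.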

Compound 4, half-maximal inhibitory concentration: > 50000 nM
Compound 4 was reported as a limit; the forecaster's own chance of this, stated with the estimate: 80%; the middle value sits exactly at the limit.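

For the compounds shown here, compound 2 and compound 4 are both reported only as limits in this assay, so no step between them can be read, and every value shown sits at the same limit: the limit of > 50000 nM in this assay, at which 4 of the 4 values shown sit. The compounds shown leave open whether any change on the shared core alters antiproliferative activity at all.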